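Straight Chain for Branched: Compound 4 Expected Unchanged

The compounds below may be only part of what the source reports. "The series", "measured", "known", "first", "only" and "open" are said of these compounds alone.

Three compounds have been measured in an ADME assay on the whole organism with Oryza sativa as the target, tested at 0.1 uM; on this read-out lower numbers stand for a stronger effect and higher numbers for a weaker effect at the one concentration tested:
Compound 1, `CCc1ccc(NC(=O)N[C@@H](C)c2ccccc2)cc1`, gives 99%.
Compound 2, `CC(C)c1ccc(NC(=O)N[C@@H](C)c2ccccc2)cc1`, gives 98%.
Compound 3, `C[C@H](NC(=O)Nc1ccc(C(C)(C)C)cc1)c1ccccc1`, gives 100%.

Compound 3 carries the highest number on paper, but the steps of a number 1 percentage points higher from compound 1 to compound 3 (within the scatter) and a number 2 percentage points higher from compound 2 to compound 3 (within the scatter) are both within the scatter, so the three compounds cannot be told apart in this assay.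

Compound 4, `CCCCc1ccc(NC(=O)N[C@@H](C)c2ccccc2)cc1`, has not yet been measured. Its change from compound 3 is butyl in place of tert-butyl on an aromatic carbon. Going by the values given here, no measured step swaps a branched group for a straight one; the nearest guides are a number 1 percentage points higher from compound 1 to compound 3 (within the scatter) and a number 1 percentage points lower from compound 1 to compound 2 (within the scatter), where adding or rearranging carbon on that side of the shared core changed nothing beyond the scatter. A step of no more than the scatter is therefore expected, a number 2 percentage points lower from compound 3 to compound 4 (within the scatter). Compound 4 is estimated at 98%, between 92% and 100%.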

Compound 4, a percentage reported as activity, at one concentration (the size of the read-out at that concentration, not a potency): 98%
Compound 4: middle estimate and measured number agree at the digits printed; the measured number falls inside the stated range.
By their numbers in this assay, from the lowest: compounds 2, 4, 1 and 3 (each within the scatter of the next).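

In this assay, swapping the branched group for a straight chain built from the same atoms makes no difference that can be told from the scatter (a number 2 percentage points lower from compound 3 to compound 4 (within the scatter)), so at this place, para to a large group, the arrangement of these carbons does not show in the read-out. Butyl also cannot be told apart from isopropyl (no change at the digits printed from compound 2 to compound 4 (within the scatter)) or from the shorter ethyl chain (a number 1 percentage points lower from compound 1 to compound 4 (within the scatter)). No measurement at hand offers a reason for this flat picture.

All four groups are plain carbon chains. Going by these compounds, whether an amine, a carboxylic acid or a longer chain at this place would move the number remains open.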